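Hydroxy in place of hydrogen on the carboxy-bearing ring

A few compounds are considered here, and "the series" means these few. Any claim that something is new, unique, unknown or untested is made for them only; others in the source may bear on it.

Measured so far:
compound 1 `CCCCCCC(C(=O)O)n1cnc(NC(=O)c2ccccc2C(=O)O)c1` 100 nM
compound 2 `CCCCCCC(C(=O)O)n1cnc(NC(=O)c2ccccc2C2N=NN=N2)c1` 100 nM

In a functional assay (aorta) with Oryctolagus cuniculus as the target (a higher number here means weaker binding, a lower number tighter binding), compound 1 gives 100 nM, and in the same measurement compound 2 gives 100 nM. Among the measured compounds shown here, the one step recorded, no change at the digits printed from compound 1 to compound 2 (within the scatter), shows that exchanging the carboxy group for the five-membered ring of one carbon and four nitrogen atoms leaves the dissociation constant where it was. Compound 1 therefore stands level with compound 2, with nothing to separate them beyond the scatter.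

Compound 3 `CCCCCCC(C(=O)O)n1cnc(NC(=O)c2cccc(O)c2C(=O)O)c1` differs from compound 1 by hydroxy in place of hydrogen on an aromatic carbon. The new group sits on an aromatic carbon of the six-membered aromatic ring of carbon only, ortho to the carboxy group and meta to the large group. For the measured compounds named here, the only measured step bears on this change just indirectly: it concerns the carboxy group itself, which in compound 3 is kept, and no measured pair shows a hydroxy entering anywhere. With the ring tolerating a far larger swap without a shift in this assay, a step of no change at the digits printed from compound 1 to compound 3 (within the scatter) is expected, that is none beyond the scatter, but the range is kept wide for lack of a direct precedent. Compound 3 is estimated at 100 nM, between 30 nM and 400 nM.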

Compound 3, dissociation constant: 100 nM
Beside the measured number, compound 3's estimate shows no gap at the digits printed; the measured number falls inside the stated range.
By their numbers in this assay, from the lowest: compounds 1, 2 and 3 (each within the scatter of the next).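

Hydroxy in place of hydrogen on an aromatic carbon, ortho to a carboxy group and meta to a large group, gives no change at the digits printed from compound 1 to compound 3 (within the scatter) in this assay. The earlier step, no change at the digits printed from compound 1 to compound 2 (within the scatter), exchanged the carboxy group itself, whereas this one keeps that group and shows that a second site on the same ring, one that carried only hydrogen in compound 1, also accepts a new group with a hydrogen-bond donor and acceptor without a shift beyond the scatter. No measurement at hand offers an explanation for this flat result.

Open, going by these compounds, is whether methoxy or an amine on this same aromatic carbon would also leave the dissociation constant in place, and whether hydroxy on the other carbons of the ring would do the same. Also open, on these data alone, is whether hydroxy at this place reads the same on the core of compound 2, where the five-membered ring stands instead of the carboxy group, and whether a longer chain on the shared core would move the value at all.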